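The compounds below may be only part of what the source reports. "The series", "measured", "known", "first", "only" and "open" are said of these compounds alone.

Among the compounds with values here, in an ADME assay on microsomes from liver (Rattus norvegicus) for metabolic stability, read by LC-MS, with a stated time of 10 min, tested at 0.5 uM (on this read-out higher numbers stand for a more stable compound and lower numbers for a less stable compound), compound 1 `c1ccc2c(c1)CN[C@H](CN(CCCN1CCNCC1)[C@H]1CCCc3cccnc31)C2` gives 88%, the highest of the three numbers so far. Compound 3 `c1ccc2c(c1)CN[C@@H](CN(CCN1CCNCC1)[C@H]1CCCc3cccnc31)C2` follows at 62% and compound 2 `c1ccc2c(c1)CN[C@@H](CN(CCC1CCNCC1)[C@H]1CCCc3cccnc31)C2` at 17%, both beyond the scatter from compound 1.

Compound 4 `c1cnc2c(c1)CN[C@@H](CN(CCCN1CCNCC1)[C@H]1CCCc3cccnc31)C2` has not yet been measured. Its difference from compound 1 is a group of 10 heavy atoms (8 carbon, 2 nitrogen; one six-membered non-aromatic ring with 1 hetero atom, one six-membered aromatic ring with 1 hetero atom) in place of a group of 10 heavy atoms (9 carbon, 1 nitrogen; one six-membered non-aromatic ring with 1 hetero atom, one six-membered aromatic ring of carbon only), on a saturated chain carbon bound to an amine nitrogen. In plain terms, the six-membered aromatic ring of carbon only gives way to a six-membered aromatic ring with 1 hetero atom.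

Within the data shown here, only one measured step bears on this, and only indirectly: a number 45 percentage points higher from compound 2 to compound 3 (beyond the scatter). That large step came from piperazin-1-yl in place of piperidin-4-yl, which is a different exchange. It shows that one exchange of a group can move this read-out a long way, but it gives neither size nor direction for the present change. With compound 1 at 88%, little room remains upward, so a modest fall is the more likely outcome.

The expected step is a number 8 percentage points lower from compound 1 to compound 4 (within the scatter), though the uncertainty is wide. The estimate for compound 4 is 80%, with an expected range from 58% to 96%.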

Compound 4, percent of the compound remaining: 79%
The estimate for compound 4 lay 1 percentage points above the measured number, and the stated range covers the measured number.
By their numbers in this assay, from the lowest: compound 2; then compound 3; then compounds 4 and 1 (each within the scatter of the next).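

The exchange of the six-membered aromatic ring of carbon only for a six-membered aromatic ring with 1 hetero atom leaves this assay within the usual scatter (a number 9 percentage points lower from compound 1 to compound 4 (within the scatter)). Within the data shown here, the earlier step concerned a different place in the molecule, so this is the first sign that, on a saturated chain carbon bound to an amine nitrogen, this ring exchange is tolerated, at least with the side chain of compound 1. Nothing measured here accounts for this result.

As far as these compounds go, it remains open whether a pyrimidine ring, or a chlorine or methoxy group on the aromatic ring, would give a similar number. From the compounds shown here alone, it is also open whether the same ring exchange would behave alike with the piperidin-4-yl chain of compound 2, the least stable compound so far.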